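A few compounds are considered here, and "the series" means these few. Any claim that something is new, unique, unknown or untested is made for them only; others in the source may bear on it.

Compound 1 `COc1cc(C(=O)NS(=O)(=O)c2ccccc2C)ccc1Cn1ncc2ccc(NC(=O)OC3CCCC3)cc21` was tested in a functional assay (trachea) for antagonist activity, with Cavia porcellus as the target (a lower number here means a less potent compound, a higher number a more potent compound, by a factor of ten per unit of this negative logarithm), where compound 1 gives 10.2. That is the highest of the three numbers measured, although the nearest one, that of compound 2 `COc1cc(C(=O)NS(=O)(=O)c2ccccc2C)ccc1Cn1ccc2ccc(NC(=O)CC3CCCC3)cc21`, which in this assay gives 9.9, lies within the scatter of repeated measurements, so the two cannot be ranked. Compound 3 `CCCCC(CC)C(=O)Nc1ccc2ccn(Cc3ccc(C(=O)NS(=O)(=O)c4ccc([N+](=O)[O-])cc4)cc3OC)c2c1` differs from compound 1 in several places. In this assay compound 3 gives 7.7, a number well beyond the scatter below compound 1.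

Compound 4 `COc1cc(C(=O)NS(=O)(=O)c2ccccc2C)ccc1Cn1ncc2ccc(NC(=O)CC3CCCC3)cc21` has not yet been measured. It differs from compound 1 in one place only: cyclopentylmethyl in place of cyclopentyloxy on a carbonyl carbon. Going by the values given here, no pair of measured compounds differs by exactly this change, so no measured step shows its size. The change does bring compound 4 close to compound 2, which carries the same cyclopentylmethyl carbonyl group on a different version of the shared core and gives 9.9. On that basis the step from compound 1 to compound 4 is expected to be small, a number 0.20 log units lower from compound 1 to compound 4 (within the scatter), not beyond the scatter. Compound 4 is therefore estimated to give 10 in this assay, with a likely range from 9.5 to 10.5.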

Compound 4, negative logarithm of the antagonist equilibrium constant: 10.9
Beside the measured number, compound 4's estimate is 0.90 log units below it; the measured number lies above the stated range.
By their numbers in this assay, from the lowest: compound 3; then compounds 2 and 1 (each within the scatter of the next); then compound 4.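

The one-place exchange of cyclopentyloxy for cyclopentylmethyl on a carbonyl carbon gives, in this assay, a number 0.70 log units higher from compound 1 to compound 4 (beyond the scatter). Both groups have 6 heavy atoms and a five-membered non-aromatic ring of carbon only, and the exchange swaps the oxygen for a carbon, so even a change this small at this position can move the number beyond the scatter. Nothing available here explains why the cyclopentylmethyl compound gives the higher number.

On these data alone, whether the same exchange would give a step of similar size on the core of compound 2 remains open. Also open, as far as these compounds go, is how a cyclopentylamino group or a longer chain, such as cyclopentylethyl, would compare with cyclopentylmethyl on this carbonyl carbon.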